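Swapping tert-Butyl for Phenoxy: What to Expect

A few compounds are considered here, and "the series" means these few. Any claim that something is new, unique, unknown or untested is made for them only; others in the source may bear on it.

Of the compounds shown here, two have been measured in an assay for inhibition of Amine oxidase [flavin-containing] A (Homo sapiens), read by fluorescence and spectrophotometry, using microsomes, with stated times of 30 min and 20 min; a higher number here means a weaker inhibitor, a lower number a stronger inhibitor. Compound 1 `c1ccc2c(c1)Oc1nccnc1N1CCN=C21` reached only a limit of the assay: in this assay compound 1 gives > 100000 nM, a boundary rather than a number. For the measured compounds named here, compound 2 `CC(C)(C)c1ccc(-c2noc(-c3ccc(C4=NCCN4)cc3)n2)cc1` is the only compound with a real number; in this assay compound 2 gives 751 nM. Compound 3 `c1ccc(Oc2ccc(-c3noc(-c4ccc(C5=NCCN5)cc4)n3)cc2)cc1` has not yet been measured. It differs from compound 2 in one place: phenoxy in place of tert-butyl on an aromatic carbon. Going by the values given here, no measured pair shows the effect of such a swap here, so there is no step to lean on. Because compound 2 stands at 751 nM and the rest of the molecule is untouched, a step from compound 2 to compound 3 of a 1.3-fold lower number from compound 2 to compound 3 (0.10 log units; within the scatter) is expected, no larger than the usual scatter. Compound 3 is therefore estimated at 600 nM, with a likely range from 150 nM to 2500 nM.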

Compound 3, half-maximal inhibitory concentration: 2770 nM
For compound 3 the middle estimate is 4.6-fold (0.66 log units) below the measured one, outside the stated range (above it).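

In this assay, this position turns out not to be indifferent to the group it carries: phenoxy in place of tert-butyl gives a 3.7-fold higher number from compound 2 to compound 3 (0.57 log units; beyond the scatter), so compound 3 is the weaker inhibitor of the pair. A group on an aromatic carbon, para to a large group, can therefore shift the result by more than the usual scatter, and here the shift is modest and goes the unfavourable way. Nothing shown here accounts for this loss.

From the compounds shown here alone, the swap changes several things at once, so it remains open whether the oxygen, the added ring or the greater count of heavy atoms matters most. A methoxy group, which keeps the oxygen without the ring, and a cyclohexyl group, which keeps a ring without the oxygen, would help to separate these.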